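A few compounds are considered here, and "the series" means these few. Any claim that something is new, unique, unknown or untested is made for them only; others in the source may bear on it.

Compound 1 `CCN(CC)C(=O)c1sc2nc(-c3ccccc3)cc(C(F)(F)F)c2c1N` sits at the limit > 100000 nM in an ADME assay on Huh-7 cells (Homo sapiens) for cytotoxicity, read by MTT assay, with a stated time of 72 h; a lower number here means that less compound is tolerated, a higher number that more compound is tolerated. Compound 2 `COc1ccc(-c2cc(C(F)(F)F)c3c(N)c(C(N)=O)sc3n2)cc1` gives 46400 nM in this assay. Compound 3 `COc1cccc(-c2cc(C(F)(F)F)c3c(N)c(C(N)=O)sc3n2)c1` sits at the limit > 20000 nM in this assay.

So compound 3 is known only as a limit, not a number; of the three, only compound 2 has a number, and compound 1 is a second limit. The change to compound 4 `NC(=O)c1sc2nc(C3CC3)cc(C(F)(F)F)c2c1N` is cyclopropyl in place of 3-methoxyphenyl on an aromatic carbon. Going by the values given here, the single measured step, a step that the limit leaves unreadable from compound 2 to compound 3, runs into a limit and its size cannot be read, and no measured step swaps an aromatic ring for a small ring as this one does. The expected step that the limit leaves unreadable from compound 3 to compound 4 is therefore taken as small, with no direction beyond the scatter. Compound 4 is expected to give 60000 nM, within 20000 nM to 150000 nM.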

Compound 4, half-maximal cytotoxic concentration: > 20000 nM
Compound 4: no number, only a limit; the forecaster's own chance of this, stated with the estimate: 60%; the middle value lies beyond the limit too.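

Compound 4 gives only a limit, > 20000 nM. The steps to it from compound 2 and compound 3 therefore cannot be read. Going by these compounds, whether cyclopropyl in place of either methoxyphenyl changes how much compound the cells tolerate stays open.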